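This account rests on a few compounds, and the source may have more. Where it says the series, first, only, none or still open, it means among the compounds named here.

In a functional assay on A549 cells (Homo sapiens) for inhibition, read by MTT assay, with a stated time of 24 h (on this read-out higher numbers stand for weaker inhibition and lower numbers for stronger inhibition), compound 1 `CC1(C)[C@H]2CC[C@]1(C)N(Cc1cn(-c3ccccc3C#N)nn1)C(=O)C2`, which carries a 2-cyanophenyl group on an aromatic nitrogen, gives 100 nM. Compound 2 `CC1(C)[C@H]2CC[C@]1(C)N(Cc1cn(-c3cccc(Cl)c3)nn1)C(=O)C2`, with 3-chlorophenyl in that place, gives 60 nM, and compound 3 `CC1(C)[C@H]2CC[C@]1(C)N(Cc1cn(-c3ccc(O)cc3)nn1)C(=O)C2`, with 4-hydroxyphenyl, gives 140 nM. Compound 1 therefore holds the middle of these three numbers, within the usual scatter of both the others.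

Compound 4 `CC1(C)[C@H]2CC[C@]1(C)N(Cc1cn(-c3ccccc3)nn1)C(=O)C2` has hydrogen in place of cyano on an aromatic carbon, ortho to a large group, which turns 2-cyanophenyl into phenyl: hydrogen in place of cyano on an aromatic carbon. Going by the values given here, no measured compound has this bare phenyl, so the evidence is indirect. The measured steps all exchange one substituted phenyl for another. Two of them stay within the scatter: a 1.7-fold lower number from compound 1 to compound 2 (0.22 log units; within the scatter) and a 1.4-fold higher number from compound 1 to compound 3 (0.15 log units; within the scatter). The only one beyond it, and only modestly, is a 2.3-fold higher number from compound 2 to compound 3 (0.37 log units; beyond the scatter), and that step does not involve compound 1. On this basis, no step beyond the scatter is expected in this assay, in either direction, although compound 2 and compound 3 show that a modest gap can occur in this series. The expected step is a 1.1-fold lower number from compound 1 to compound 4 (0.05 log units; within the scatter). Compound 4 is estimated at 90 nM, with an expected range from 40 nM to 200 nM.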

Compound 4, half-maximal inhibitory concentration: 70 nM
Compound 4: middle estimate off by 1.3-fold (0.11 log units), on the high side; low and high end bracket the measured number.
By their numbers in this assay, from the lowest: compounds 2, 4, 1 and 3 (each within the scatter of the next, the first and the last beyond it).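

In this assay the bare phenyl of compound 4 gives the series a reference point, and removing a substituent from the ring stays within the scatter in all three comparisons: cyano (a 1.4-fold lower number from compound 1 to compound 4 (0.15 log units; within the scatter)), hydroxy (a 2.0-fold lower number from compound 3 to compound 4 (0.30 log units; within the scatter)) and chloro (a 1.2-fold higher number from compound 2 to compound 4 (0.07 log units; within the scatter)). The nitrile of 2-cyanophenyl is therefore not needed for a number of this size, and neither is the chloro or the hydroxy group of the other two compounds. The one gap beyond the scatter remains the modest one between two substituted rings (a 2.3-fold higher number from compound 2 to compound 3 (0.37 log units; beyond the scatter)), and compound 4 lies within the scatter of both, while no measurement at hand explains why these steps are so small.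

The compounds shown leave open whether this flat picture would hold for an amine, a carboxylic acid or a longer alkyl chain on the phenyl ring. They also leave open whether cyano, chloro or hydroxy would give similar numbers elsewhere on the ring, as each appears at only one place here.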